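The source may report more compounds than this note shows. Statements on the series, on what has been measured and on what is new or still open speak of the compounds shown alone.

Working notes on the series, read in an ADME assay on cells (Hepatocyte, Mus musculus) for cytotoxicity, read by MTT assay, with a stated time of 24 h; a lower number here means that less compound is tolerated, a higher number that more compound is tolerated. Compound 1 `Cc1ccc(C)c(S(=O)(=O)n2c(-c3cn(-c4ccccc4)nc3-c3ccc(C(F)(F)F)cc3)nc3ccccc32)c1` gives 132000 nM, and compound 2 `O=S(=O)(c1ccc(F)cc1)n1c(-c2cn(-c3ccccc3)nc2-c2ccc(C(F)(F)F)cc2)nc2ccccc21` gives 83300 nM. Compound 2 therefore stands within the scatter of compound 1, the only other measured point. The next structure is compound 3 `O=S(=O)(c1ccc(Cl)cc1)n1c(-c2cn(-c3ccccc3)nc2-c2ccc(C(F)(F)F)cc2)nc2ccccc21`, which has chloro in place of fluoro on an aromatic carbon, para to a large group (chloro in place of fluoro on an aromatic carbon). Going by the values given here, only one measured step bears on this change: a 1.6-fold lower number from compound 1 to compound 2 (0.20 log units; within the scatter), with 4-fluorophenyl in place of 2,5-dimethylphenyl on a sulfonyl sulfur. That step replaced a whole aryl group, and no exchange of one halogen for another has been measured, so it is only a loose guide. No step beyond the scatter is expected in this assay, in either direction. The expected step is a 1.1-fold lower number from compound 2 to compound 3 (0.03 log units; within the scatter). Compound 3 is estimated at 78000 nM, with an expected range of 40000 nM to 150000 nM.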

Compound 3, half-maximal cytotoxic concentration: 173000 nM
Compound 3: middle estimate off by 2.2-fold (0.35 log units), on the low side, outside the stated range (above it).
By their numbers in this assay, from the lowest: compounds 2, 1 and 3 (each within the scatter of the next, the first and the last beyond it).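

In this assay, going by these compounds alone, the first exchange of one halogen for another, on an aromatic carbon para to a large group, gives a 2.1-fold higher number from compound 2 to compound 3 (0.32 log units; beyond the scatter) and shows that this single-atom change can move the number beyond the scatter, towards more compound tolerated. Replacing the whole aryl group gives a 1.3-fold higher number from compound 1 to compound 3 (0.12 log units; within the scatter) and so separates 4-chlorophenyl from 2,5-dimethylphenyl no more than the scatter allows, which leaves compound 1 within the scatter of both halogen compounds. Nothing available explains the gap between fluoro and chloro at this position.

On these data alone, whether bromo or methoxy on the same aromatic carbon would follow chloro or fall back towards fluoro remains open. Also open, as far as these compounds go, is how an amine or a carboxylic acid at this position would read, since the halogen effect rests on one pair alone.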